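Replacing 1-Benzofuran-2-yl with 2-Carboxyphenoxy on a Shared Core

The compounds below may be only part of what the source reports. "The series", "measured", "known", "first", "only" and "open" are said of these compounds alone.

Measured compounds:
compound 1 `Cc1ccccc1-n1nc(C)c2c1NC(=O)[C@H](C)S[C@@H]2c1ccc(-c2cccc(C(=O)O)c2)cc1` — "not active" (no number reported)
compound 2 `Cc1ccccc1-n1nc(C)c2c1NC(=O)[C@H](C)S[C@@H]2c1ccc(-c2cc3ccccc3o2)cc1` — 1500 nM
compound 3 `Cc1nn(-c2ccccc2F)c2c1C(c1ccc(Oc3ccccc3)cc1)SC(C)C(=O)N2` — 3900 nM

In an assay on isolated protein for agonist activity at Bile acid receptor (Homo sapiens), read by AlphaScreen, with a stated time of 30 min (on this read-out higher numbers stand for an effect only at larger amounts of compound and lower numbers for an effect already at smaller amounts), compound 2 gives 1500 nM, the lowest of the two numbers reported. Compound 3 stands above it, and the gap between them lies beyond the scatter. Compound 1 is reported as not active, with no number given.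

Compound 4 `Cc1ccccc1-n1nc(C)c2c1NC(=O)[C@H](C)S[C@@H]2c1ccc(Oc2ccccc2C(=O)O)cc1` differs from compound 2 in one place: 2-carboxyphenoxy in place of 1-benzofuran-2-yl on an aromatic carbon. Among the compounds with values here, no measured pair shows this exact change. Within the data shown here, since compound 1, the only other compound carrying an acid, is reported as "not active" (no number reported), the step of a 5.3-fold higher number from compound 2 to compound 4 (0.73 log units; beyond the scatter) is expected to be upward and beyond the scatter. In this assay compound 4 is therefore estimated at 8000 nM, with a range from 2500 nM to 30000 nM.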

Compound 4, half-maximal effective concentration: "not active" (no number reported)
Compound 4 has no reported number here; no gap can be computed for the estimate.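

In this assay, within the data shown here, compound 4, like compound 1, carries no number, and no step from compound 2 to compound 4 can be read. The compounds shown leave open how far compound 4 lies from compound 2, and no evidence at hand bears on this result.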